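Series notes: ring swap on the sulfonyl sulfur

This account rests on a few compounds, and the source may have more. Where it says the series, first, only, none or still open, it means among the compounds named here.

Three close analogues have been measured. In a functional assay on IMR-32 cells (Homo sapiens) for cytotoxicity, read by MTT assay, tested at 60 ug/mL (on this read-out higher numbers stand for more inhibition at the one concentration tested (going by the name of the read-out) and lower numbers for less inhibition), compound 1 `CCNC(=O)CCC(NS(=O)(=O)c1cc(Cl)ccc1Cl)C(=O)NCC` gives 12.9%; compound 3 `CCCNC(=O)CCC(NS(=O)(=O)c1cc(C)ccc1Cl)C(=O)NCCC` gives 14.9%; compound 2 `CCCCNC(=O)CCC(NS(=O)(=O)c1cc(Cl)ccc1Cl)C(=O)NCCCC` gives 15.8%, the highest of the three numbers, though both compound 3 and compound 1 lie within the scatter of it, so no order among them can be read. Going by the values given here, no pair of measured compounds differs in a single place, so no measured step size is available. Compound 4 `CCCCNC(=O)CCC(NS(=O)(=O)c1ccc(C)cc1C)C(=O)NCCCC` differs from compound 2 in one place: 2,4-dimethylphenyl in place of 2,5-dichlorophenyl on a sulfonyl sulfur. With nothing measured to lean on, the expected step from compound 2 to compound 4 in this assay is a number 0.8 percentage points lower from compound 2 to compound 4 (within the scatter), meaning none beyond the scatter in either direction. Compound 4 is therefore estimated at 15%, with a range from 5% to 27%.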

Compound 4, a percentage reported as inhibition, at one concentration (the size of the read-out at that concentration, not a potency): 46.1%
For compound 4 the middle estimate is 31.1 percentage points below the measured one; measured number above the stated range.
By their numbers in this assay, from the lowest: compounds 1, 3 and 2 (each within the scatter of the next); then compound 4.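

In this assay the change to 2,4-dimethylphenyl in place of 2,5-dichlorophenyl on a sulfonyl sulfur gives a number 30.3 percentage points higher from compound 2 to compound 4 (beyond the scatter) with the rest of the molecule unchanged. This first single-place step shows that the read-out responds to the ring at this position, which the three earlier numbers could not show. Nothing measured here accounts for the step.

This single swap cannot separate the loss of chlorine from the gain of methyl or from the change in their placement. On these data alone, how a ring bearing a methoxy or an amine would read also stays open.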